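Benzyl esters and side-chain size in the tail flick series

This account rests on a few compounds, and the source may have more. Where it says the series, first, only, none or still open, it means among the compounds named here.

Measured so far in a functional assay on the whole organism (Tail, strain ICR) with Mus musculus as the target, in the tail flick test, with a stated time of 90 min, at a dose of 25 umol/kg by the oral route; on this read-out lower numbers stand for a weaker effect and higher numbers for a stronger effect at the one dose given:
compound 1, `N=C(N)NCCC[C@H](NC(=O)CN(c1nc(Cl)nc2[nH]cnc12)C1CC1)C(=O)OCc1ccccc1`, 30.4%
compound 2, `NC(=O)CC[C@H](NC(=O)CN(c1nc(Cl)nc2[nH]cnc12)C1CC1)C(=O)O`, 41.1%
compound 3, `C[C@H](NC(=O)CN(c1nc(Cl)nc2[nH]cnc12)C1CC1)C(=O)OCc1ccccc1`, 44.2%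

Compound 3 holds the highest of the three numbers, though compound 2 sits within the scatter of it; only compound 1 lies beyond the scatter below it. Compound 4, `NC(=O)CC[C@H](NC(=O)CN(c1nc(Cl)nc2[nH]cnc12)C1CC1)C(=O)OCc1ccccc1`, differs from compound 3 by carbamoylmethyl in place of hydrogen on a saturated chain carbon, two bonds along the chain from an amide-type nitrogen and a carbonyl carbon. Among the compounds with values here, the one step that bears on it is a number 13.8 percentage points higher from compound 1 to compound 3 (beyond the scatter), where a side chain at the same place came off. Adding a shorter side chain in compound 4 is therefore expected to cost a little, if anything, in this assay, roughly a number 6.2 percentage points lower from compound 3 to compound 4 (within the scatter). Compound 4 is estimated at 38%, between 25% and 50%.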

Compound 4, a percentage reported as activity, at one dose (the size of the read-out at that dose, not a potency): 42.8%
The estimate for compound 4 lay 4.8 percentage points below the measured number; measured number inside the range.
By their numbers in this assay, from the lowest: compound 1; then compounds 2, 4 and 3 (each within the scatter of the next).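

In this assay, not every side chain at this saturated chain carbon lowers the number: carbamoylmethyl in place of hydrogen gives a number 1.4 percentage points lower from compound 3 to compound 4 (within the scatter), while the change at the end of the side chain gives a number 12.4 percentage points higher from compound 1 to compound 4 (beyond the scatter). Benzyl in place of hydrogen on an oxygen next to a carbonyl group also makes no difference beyond the scatter, with a number 1.7 percentage points higher from compound 2 to compound 4 (within the scatter). No available evidence accounts for these numbers.

From the compounds shown here alone, whether an amine, a carboxylic acid or a longer chain at this carbon would keep the number remains open. So does whether the benzyl step would read the same with other side chains.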